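The source may hold more compounds than are shown below. What is called first, only, known or untested is meant among the compounds shown, and "the series" means these compounds.

Measured compounds in an in vitro ADME assay on microsomes from liver (Homo sapiens) for pharmacokinetics, read by LC-MS, with a stated time of 10 min, tested at 1 uM; on this read-out higher numbers stand for fast clearance and lower numbers for slow clearance:
- compound 1 `CN1C[C@H](C(=O)Nc2ccc(C(F)(F)F)cc2)[C@@H](c2ccc(/C=C/C(=O)Nc3ccccc3N)cc2)C1`: 6 mL/min/kg
- compound 2 `CN1C[C@H](C(=O)Nc2cccc(Cl)c2)[C@@H](c2ccc(/C=C/C(=O)Nc3ccccc3N)cc2)C1`: 7 mL/min/kg
- compound 3 `CN1C[C@H](C(=O)Nc2ccccc2F)[C@@H](c2ccc(/C=C/C(=O)Nc3ccccc3N)cc2)C1`: 10 mL/min/kg

Compound 1 has the lowest number of the three, but the gaps to compound 2 a 1.2-fold higher number from compound 1 to compound 2 (0.07 log units; within the scatter) and to compound 3 a 1.7-fold higher number from compound 1 to compound 3 (0.22 log units; within the scatter) both lie within the scatter, as does the gap from compound 2 to compound 3 a 1.4-fold higher number from compound 2 to compound 3 (0.15 log units; within the scatter). On these numbers the three compounds are not distinguishable.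

Compound 4 `CN1C[C@H](C(=O)N2CCCCC2)[C@@H](c2ccc(/C=C/C(=O)Nc3ccccc3N)cc2)C1` differs from compound 1 as follows: piperidin-1-yl in place of (4-(trifluoromethyl)phenyl)amino on a carbonyl carbon. Among the compounds with values here, none of the measured steps covers a change of this kind; all three exchange one aryl group on the amide nitrogen for another, and all three sit within the scatter. They show only that variation of the amide substituent within this series has so far left the number in this assay roughly unchanged. Within the data shown here, with no step that bears directly on the change, the expectation for compound 4 rests on the narrow spread of the measured set and is given a wide range.

Compound 4 is expected to give about 9 mL/min/kg in this assay, with a range of 4 mL/min/kg to 22 mL/min/kg. This estimate means a step of a 1.5-fold higher number from compound 1 to compound 4 (0.18 log units; within the scatter), which is not expected to exceed the scatter.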

Compound 4, clearance: 9 mL/min/kg
For compound 4 middle estimate and measured number coincide at the digits printed; the range from low to high includes it.
By their numbers in this assay, from the lowest: compounds 1, 2, 4 and 3 (each within the scatter of the next).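

In this assay the change to piperidin-1-yl on the carbonyl carbon gives a 1.5-fold higher number from compound 1 to compound 4 (0.18 log units; within the scatter) and a 1.3-fold higher number from compound 2 to compound 4 (0.11 log units; within the scatter) and a 1.1-fold lower number from compound 3 to compound 4 (0.05 log units; within the scatter) with no step beyond the scatter. The earlier compounds shown here only exchanged one aryl group for another, whereas compound 4 has neither the aromatic ring nor the amide hydrogen of those compounds, and its number still cannot be told apart from theirs. The data shown offer no measurement that would explain this tolerance at the position.

Still open, on these data alone, is whether a carboxylic acid, or a longer chain ending in an amine, on this carbonyl carbon would also stay within the scatter of compound 4. Also open, as far as these compounds go, is whether this tolerance extends to any read-out other than clearance.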